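This account rests on a few compounds, and the source may have more. Where it says the series, first, only, none or still open, it means among the compounds named here.

Measured compounds in a functional assay on A2780 cells (Homo sapiens) for antiproliferative activity, read by fluorescence, with a stated time of 72 h; on this read-out higher numbers stand for weaker inhibition and lower numbers for stronger inhibition:
compound 1 `CC1(C)c2[nH]nc(NC(=O)c3ccc(F)cc3)c2CN1C(=O)C1CCN(C2CC2)CC1` gives 380 nM
compound 2 `CC(C)CC(=O)Nc1n[nH]c2c1CN(C(=O)C1CCN(C3CC3)CC1)C2(C)C` gives 320 nM
compound 3 `CC(C)(C)C(=O)N1Cc2c(NC(=O)c3cccnc3)n[nH]c2C1(C)C` gives 690 nM

Compound 1 stands second highest of the three numbers; its nearest neighbour is compound 2 and its furthest is compound 3, and both gaps lie within the scatter, so these three values do not separate the compounds from one another. Within the data shown here, the only step that differs in one place, a 1.2-fold lower number from compound 1 to compound 2 (0.07 log units; within the scatter), exchanges one acyl group on the amide carbonyl for another and leaves the number essentially where it was.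

Compound 4 `CC(=O)N1CCC(C(=O)N2Cc3c(NC(=O)c4ccc(F)cc4)n[nH]c3C2(C)C)CC1` is the unmeasured analogue of compound 1. The change is acetyl in place of cyclopropyl on an amine nitrogen in a ring, which sits on the six-membered ring at the far end of the molecule from the amide. Among the measured compounds shown here, no measured step touches this position: the acyl swap concerns the amide carbonyl, and compound 3 differs in several places at once. For the measured compounds named here, the series so far is flat, which argues for a small step, but the absence of any precedent at the ring nitrogen widens the range. For compound 4 the expected step is a 1.4-fold higher number from compound 1 to compound 4 (0.16 log units; within the scatter). Compound 4 is estimated at 550 nM, with a range from 200 nM to 1600 nM.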

Compound 4, half-maximal inhibitory concentration: > 10000 nM
Compound 4: only a limit was reported; the forecaster's own chance of this, stated with the estimate: 3%; middle value at least 18-fold (1.25 log units) from the limit.
By their numbers in this assay, from the lowest: compounds 2, 1 and 3 (each within the scatter of the next, the first and the last beyond it). At a limit, above all of these: compound 4.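

Among these compounds, of the steps read so far, only the one at the amine nitrogen of the six-membered ring goes beyond the scatter: in this assay, acetyl in place of cyclopropyl gives an at least 26-fold higher number from compound 1 to compound 4 (1.42 log units; beyond the scatter), so this position responds far more strongly than the flat values at the amide carbonyl suggested. As far as these compounds go, compound 4 is reported only as a limit, > 10000 nM, so the true size of the step stays unknown and only its lower bound can be read: the limit of > 10000 nM in this assay, at which 1 of the 4 values shown sits. Cyclopropyl and acetyl match in heavy-atom count, while acetyl brings a hydrogen-bond acceptor and no ring, so heavy-atom count alone does not track the read-out at this nitrogen.

A single pair cannot separate the part played by the entering acetyl from the part played by the departing cyclopropyl ring, and a plain alkyl group such as ethyl or isopropyl on the same nitrogen, or a methanesulfonyl group there, would help to pull the two apart. Also open, from the compounds shown here alone, is whether the same step holds when the 4-fluorophenyl on the amide carbonyl is replaced by the isobutyl of compound 2.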